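Sulfur-linked side chains on a shared core: compound 4

This account rests on a few compounds, and the source may have more. Where it says the series, first, only, none or still open, it means among the compounds named here.

Measured compounds:
compound 1 `CC(C)c1n[nH]c2c(NCc3ccc(-c4ccccn4)cc3)nc(SCC(N)=O)nc12`: 192 nM
compound 2 `CC(C)c1n[nH]c2c(NCc3ccc(-c4ccccn4)cc3)nc(SCCCN(C)C)nc12`: 105 nM
compound 3 `CC(C)c1n[nH]c2c(NCc3ccc(-c4ccccn4)cc3)nc(SC3CCCCC3N)nc12`: 139 nM

Three compounds sharing one core differ only in the group attached to the sulfur. In a functional assay on HT cells (Homo sapiens) for antiproliferative activity, read by fluorescence, with a stated time of 72 h (a lower number here means a stronger inhibitor of growth, a higher number a weaker inhibitor of growth), compound 1 gives 192 nM, the highest of the three numbers, yet its nearest neighbour compound 3 sits only a 1.4-fold lower number from compound 1 to compound 3 (0.14 log units; within the scatter) away and compound 2, the furthest, at a 1.8-fold lower number from compound 1 to compound 2 (0.26 log units; within the scatter), both within the scatter. Compound 2 and compound 3 are likewise close to each other, a 1.3-fold higher number from compound 2 to compound 3 (0.12 log units; within the scatter).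

Compound 4 `CC(C)c1n[nH]c2c(NCc3ccc(-c4ccccn4)cc3)nc(SCCNC(N)=O)nc12` is not yet measured. Relative to compound 1 the change is ureidomethyl in place of carbamoyl on a saturated chain carbon bound to a sulfur. The steps from compound 1 to compound 2 and from compound 1 to compound 3 both alter the same sulfur-bound chain, and neither moved this assay beyond the scatter, so the expected step for compound 4 in this assay is a 1.1-fold lower number from compound 1 to compound 4 (0.05 log units; within the scatter), that is, none beyond the scatter. On that basis compound 4 is estimated at 170 nM, expected to lie between 80 nM and 360 nM.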

Compound 4, concentration for 50% growth inhibition: 240 nM
Beside the measured number, compound 4's estimate is 1.4-fold (0.15 log units) below it; the range from low to high includes it.
By their numbers in this assay, from the lowest: compounds 2, 3, 1 and 4 (each within the scatter of the next, the first and the last beyond it).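

In this assay the 2-ureidoethyl chain on the sulfur cannot be told apart from the carbamoylmethyl chain, with a 1.3-fold higher number from compound 1 to compound 4 (0.10 log units; within the scatter), nor from the 2-aminocyclohexyl group, with a 1.7-fold higher number from compound 3 to compound 4 (0.24 log units; within the scatter), so the ureido end fits the pattern of small steps seen so far at this position. For the compounds shown here, what the earlier compounds did not show is a step beyond the scatter here: ureido in place of (dimethylamino)methyl gives a 2.3-fold higher number from compound 2 to compound 4 (0.36 log units; beyond the scatter), a modest gap that marks out the two ends of this small series, while compound 1 and compound 3 lie within the scatter of both ends. Nothing in the data shown accounts for this gap. 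

The compounds shown leave open whether this gap follows the end group or the length of the chain, a question that a 3-ureidopropyl chain on the sulfur would address alongside compound 2. They also leave open how a carboxylic acid or a morpholine at the end of the chain would compare with the ureido and dimethylamino ends.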